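Swapping a Dimethylamino for an Azetidine Ring

The compounds below may be only part of what the source reports. "The series", "measured", "known", "first", "only" and "open" are said of these compounds alone.

Compound 1 `CNc1nccc(N2CC[C@H](NC(=O)Nc3ccc(CN(C)C)c(C(F)(F)F)c3)C2)n1` was tested in an assay on a protein complex for displacement of a labelled ligand from CDK8/Cyclin C (Homo sapiens), read by TR-FRET, with a stated time of 1 h (a lower number here means a stronger inhibitor, a higher number a weaker inhibitor), and gives 40.1 nM. Compound 2 `CNc1nccc(N2CC[C@H](NC(=O)Nc3ccc(OC(F)(F)F)cc3)C2)n1` gives 44.1 nM in this assay, a number within the usual scatter of compound 1, so the two cannot be told apart. Compound 3 `CNc1nccc(N2CC[C@H](NC(=O)Nc3ccc(CN4CCC4)c(C(F)(F)F)c3)C2)n1` is not yet measured; it differs from compound 1 by azetidin-1-yl in place of dimethylamino on a saturated chain carbon bound to an aromatic carbon. For the measured compounds named here, no measured pair isolates this change. The change is expected to matter little, a 1.0-fold lower number from compound 1 to compound 3 (0.00 log units; within the scatter), with no direction beyond the scatter. Compound 3 is expected to give 40 nM, within 18 nM to 90 nM.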

Compound 3, half-maximal inhibitory concentration: 99.9 nM
The estimate for compound 3 lay 2.5-fold (0.40 log units) below the measured number; measured number outside the range, above it.
By their numbers in this assay, from the lowest: compounds 1 and 2 (each within the scatter of the next); then compound 3.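

Azetidin-1-yl in place of dimethylamino on a saturated chain carbon bound to an aromatic carbon gives a 2.5-fold higher number from compound 1 to compound 3 (0.40 log units; beyond the scatter) in this assay, a modest step but beyond the scatter. This position therefore responds to the group it carries, even though the counts of hydrogen-bond donors and acceptors stay the same and neither group carries a net charge. No measurement shown here accounts for the step.

As far as these compounds go, whether the number keeps rising with other rings remains open. A pyrrolidine, a piperidine or a morpholine on the same carbon would show whether the four-membered ring is a special case.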